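The source may hold more compounds than are shown below. What is called first, only, known or untested is meant among the compounds shown, and "the series" means these compounds.

Three esters and amides of a shared core have been tested in an assay on membranes from CHO cells for displacement of a labelled ligand from adenosine receptor A1 (Homo sapiens), read by scintillation counting, with a stated time of 60 min, tested at 1 uM; on this read-out lower numbers stand for less inhibition and higher numbers for more inhibition at the one concentration tested (going by the name of the read-out). Compound 1 `CC1=C(C(=O)OCc2ccccc2)C(c2ccco2)NC(=O)N1` gives 36%, compound 2 `CCNC(=O)C1=C(C)NC(=O)NC1c1ccco1` gives 2%, and compound 3 `CCC(C)OC(=O)C1=C(C)NC(=O)NC1c1ccco1` gives 6%. Compound 3 thus stands second of the three, close to compound 2 and well below compound 1. Compound 4 `CC1=C(C(=O)OC2CCCCC2)C(c2ccco2)NC(=O)N1` differs from compound 3 only by cyclohexyl in place of sec-butyl on an oxygen next to a carbonyl group. Going by the values given here, two measured steps bear on this. At the same position, the step of a number 30 percentage points lower from compound 1 to compound 3 (beyond the scatter) shows that the group on this oxygen can move the read-out by a modest amount, while the step of a number 4 percentage points higher from compound 2 to compound 3 (within the scatter) stayed within the scatter. Compound 4 is therefore expected to show a step of a number 8 percentage points higher from compound 3 to compound 4 (within the scatter) in this assay, a small rise of uncertain size. The estimate for compound 4 is 14%, ranging from 0% to 35%.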

Compound 4, a percentage reported as inhibition, at one concentration (the size of the read-out at that concentration, not a potency): 1%
Compound 4: middle estimate off by 13 percentage points, on the high side; measured number inside the range.
By their numbers in this assay, from the lowest: compounds 4, 2 and 3 (each within the scatter of the next); then compound 1.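

Cyclohexyl on this oxygen reads the same as sec-butyl (a number 5 percentage points lower from compound 3 to compound 4 (within the scatter)), and compound 4 also stays level with the ethylamino amide, compound 2 (a number 1 percentage points lower from compound 2 to compound 4 (within the scatter)). Carrying a ring on this oxygen is therefore not enough in itself, since cyclohexyl does not keep what benzyl gives (a number 35 percentage points lower from compound 1 to compound 4 (beyond the scatter)). No measurement at hand explains this gap between benzyl and cyclohexyl. Still open, from the compounds shown here alone, is whether the phenyl ring of benzyl alone matters, or also the carbon joining it to the oxygen, which a phenyl or a cyclohexylmethyl ester would separate. Also open, going by these compounds, is how an amide bearing benzyl on its nitrogen would read.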